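Trading the larger ring on the sulfur for a smaller one

A few compounds are considered here, and "the series" means these few. Any claim that something is new, unique, unknown or untested is made for them only; others in the source may bear on it.

Compound 2 `O=[N+]([O-])c1ccc(S(=O)(=O)Nc2ccc(O)c(Sc3ncnc4nc[nH]c34)c2)cc1` stands highest of the two compounds measured: in an assay on isolated protein for inhibition of RAC-alpha serine/threonine-protein kinase (Homo sapiens), read by fluorescence, with a stated time of 30 min, tested at 10 uM (on this read-out lower numbers stand for less inhibition and higher numbers for more inhibition at the one concentration tested (going by the name of the read-out)), compound 2 gives 37.5%. For the measured compounds named here, compound 1 `Cc1nnc(Sc2cc(NS(=O)(=O)c3ccc([N+](=O)[O-])cc3)ccc2O)s1` gives 14.3%, and the single measured step, a number 23.2 percentage points higher from compound 1 to compound 2 (beyond the scatter), turned on the same sulfur that is changed again here. Compound 3 `O=[N+]([O-])c1ccc(S(=O)(=O)Nc2ccc(O)c(Sc3nncs3)c2)cc1` differs from compound 2 as follows: a group of 5 heavy atoms (2 carbon, 2 nitrogen, 1 sulfur; one five-membered aromatic ring with 3 hetero atoms) in place of a group of 9 heavy atoms (5 carbon, 4 nitrogen; one five-membered aromatic ring with 2 hetero atoms, one six-membered aromatic ring with 2 hetero atoms), on a sulfur. The entering 1,3,4-thiadiazol-2-yl is close kin to the five-membered ring with three hetero atoms carried by compound 1, so the step that bears on this change is a number 23.2 percentage points higher from compound 1 to compound 2 (beyond the scatter) read in reverse, a modest step beyond the scatter. A fall of roughly that size, back toward the level of compound 1, is therefore expected. Compound 3 is estimated to give 18% in this assay, within 5% to 32%. This estimate means an expected step of a number 19.5 percentage points lower from compound 2 to compound 3 (beyond the scatter).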

Compound 3, a percentage reported as inhibition, at one concentration (the size of the read-out at that concentration, not a potency): 14.9%
The estimate for compound 3 lay 3.1 percentage points above the measured number; measured number inside the range.
By their numbers in this assay, from the lowest: compounds 1 and 3 (each within the scatter of the next); then compound 2.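

With the 1,3,4-thiadiazol-2-yl on the sulfur, this assay shows a number 22.6 percentage points lower from compound 2 to compound 3 (beyond the scatter) as the outcome of giving up the two-ring group, so the earlier gap also appears without the methyl. Hydrogen in place of methyl on an aromatic carbon gives a number 0.6 percentage points higher from compound 1 to compound 3 (within the scatter) and so leaves this read-out unmoved, which places the difference between the two-ring group and the five-membered ring rather than on the methyl. No measurement shown here accounts for that difference.

Going by these compounds, it remains open whether an amine on that same aromatic carbon of the five-membered ring would change the number. On these data alone, it is also open which of the two rings in the group carried by compound 2 matters, and whether any other group on the sulfur would match it.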